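Para-substituted aryl variants of the diol core

The source may hold more compounds than are shown below. What is called first, only, known or untested is meant among the compounds shown, and "the series" means these compounds.

Measured compounds:
- compound 1 `CC1(C)CCC[C@]2(C)[C@@H](CC[C@@](C)(O)/C=C/c3cccc([N+](=O)[O-])c3)[C@](C)(O)CC[C@@H]12`, in a functional assay on A549 cells (Homo sapiens) for cytotoxicity, read by MTT assay, with a stated time of 48 h (on this read-out higher numbers stand for weaker inhibition and lower numbers for stronger inhibition), compound 1 gives 3400 nM
- compound 2 `CC(C)(C)c1ccc(/C=C/[C@](C)(O)CC[C@@H]2[C@@]3(C)CCCC(C)(C)[C@@H]3CC[C@@]2(C)O)cc1`, compound 2 gives 45000 nM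
- compound 3 `CC1(C)CCC[C@]2(C)[C@@H](CC[C@@](C)(O)/C=C/c3ccc(Br)cc3)[C@](C)(O)CC[C@@H]12`, compound 3 gives 43200 nM

Compound 1 gives the lowest number of the three; compound 3 sits a 13-fold higher number from compound 1 to compound 3 (1.10 log units; beyond the scatter) and compound 2 a 13-fold higher number from compound 1 to compound 2 (1.12 log units; beyond the scatter), both beyond the scatter, while compound 2 and compound 3 lie within the scatter of each other (a 1.0-fold lower number from compound 2 to compound 3 (0.02 log units; within the scatter)).

Compound 4 `CC1(C)CCC[C@]2(C)[C@@H](CC[C@@](C)(O)/C=C/c3ccc(F)cc3)[C@](C)(O)CC[C@@H]12` is next. Its change from compound 1: 4-fluorophenyl in place of 3-nitrophenyl on a double-bonded chain carbon bound to a double-bonded chain carbon. The two steps from compound 1 that swap the 3-nitrophenyl for a 4-substituted phenyl both bear on it, and both were large and in the same direction. A similar step is therefore expected, an 8.8-fold higher number from compound 1 to compound 4 (0.95 log units; beyond the scatter), and compound 4 is estimated at 30000 nM with a range of 10000 nM to 90000 nM.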

Compound 4, half-maximal inhibitory concentration: 3100 nM
Estimate against measurement, compound 4: 9.7-fold (0.99 log units) above, and the stated range ends above it.
By their numbers in this assay, from the lowest: compounds 4 and 1 (each within the scatter of the next); then compounds 3 and 2 (each within the scatter of the next).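

Replacing 3-nitrophenyl with 4-fluorophenyl leaves the number level (a 1.1-fold lower number from compound 1 to compound 4 (0.04 log units; within the scatter)), so a 4-substituted phenyl does not by itself go with the high numbers of compounds 2 and 3. At this aromatic carbon the substituent decides the result: fluoro in place of bromo gives (a 14-fold lower number from compound 3 to compound 4 (1.14 log units; beyond the scatter)), and fluoro in place of tert-butyl gives (a 15-fold lower number from compound 2 to compound 4 (1.16 log units; beyond the scatter)). No supporting data explain this gap.

Still open, going by these compounds, is whether the low number is confined to fluoro among groups on this carbon. Chloro, methoxy or an amine there would show where the change sets in.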